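Urea to Benzamide on the Pyrazole Scaffold: Expected Loss

A few compounds are considered here, and "the series" means these few. Any claim that something is new, unique, unknown or untested is made for them only; others in the source may bear on it.

Measured compounds:
Compound 1 `COc1cc(-c2nn(-c3cccc(NC(=O)Nc4ccc(Cl)c(Cl)c4)c3)cc2-c2ccncc2)ccc1Cl` — 1440 nM
Compound 2 `O=C(Nc1cccc(-n2cc(-c3ccncc3)c(-c3ccc(Cl)c(O)c3)n2)c1)Nc1cc(C(F)(F)F)cc(C(F)(F)F)c1` — 964 nM

Two compounds carry numbers in a functional assay on HOP-62 cells (Homo sapiens) for inhibition, read by sulforhodamine B assay, with a stated time of 48 h; on this read-out lower numbers stand for stronger inhibition of growth and higher numbers for weaker inhibition of growth. Compound 1 gives 1440 nM and compound 2 gives 964 nM; the two values lie within the scatter of one another, so nothing can be said about their order, and compound 1 merely has the higher of the two numbers.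

Compound 3 `COc1cc(-c2nn(-c3cccc(NC(=O)c4ccccc4)c3)cc2-c2ccncc2)ccc1Cl` has not been measured. Starting from compound 1, the change is phenyl in place of (3,4-dichlorophenyl)amino on a carbonyl carbon. For the measured compounds named here, no measured pair shows this kind of step, so the expectation rests on compound 1 alone, whose value is 1440 nM.

Compound 3 is expected to be weaker in this assay, with a step of about a 2.8-fold higher number from compound 1 to compound 3 (0.44 log units; beyond the scatter), which would lie beyond the scatter. The estimate for compound 3 is 4000 nM, with a range from 1500 nM to 12000 nM.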

Compound 3, concentration for 50% growth inhibition: 8340 nM
Estimate against measurement, compound 3: 2.1-fold (0.32 log units) below; the range from low to high includes it.
By their numbers in this assay, from the lowest: compounds 2 and 1 (each within the scatter of the next); then compound 3.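

In this assay the substituent on this carbonyl carbon matters: phenyl in place of (3,4-dichlorophenyl)amino gives a 5.8-fold higher number from compound 1 to compound 3 (0.76 log units; beyond the scatter) and so moves the number well outside the range that the two ureas, compound 1 and compound 2, share. The change removes the amino nitrogen, with its hydrogen-bond donor, and both chlorine atoms in a single step, so this pair cannot show which of these parts accounts for the weaker inhibition of growth. No evidence at hand explains the rise.

Going by these compounds, it remains open whether plain phenylamino or a 3,4-dichlorophenyl group placed straight on the carbonyl carbon would read closer to compound 1 or to compound 3. On these data alone, how a cyclic amine such as piperidine or a longer alkyl chain would read on this carbon also remains open.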